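The source may report more compounds than this note shows. Statements on the series, on what has been measured and on what is new or still open speak of the compounds shown alone.

For the measured compounds named here, compound 1 `COc1cc2c(Nc3nc4ccc(C(=O)Nc5c(C)cccc5Cl)cc4s3)ncnc2cc1OCCCN1CCCCC1C` is the only member of this small set for which a functional assay on NCI-H661 cells (Homo sapiens) for cytotoxicity, read by WST assay, with a stated time of 72 h (on this read-out higher numbers stand for weaker inhibition and lower numbers for stronger inhibition), returns a number: in this assay compound 1 gives 5300 nM. Compound 2 `COc1cc2c(Nc3nc4ccc(C(=O)Nc5c(C)cccc5C)cc4s3)ncnc2cc1OCCCN1CCCC1` reaches only a limit of the assay, > 100000 nM. Compound 3 `COc1cc2c(Nc3nc4ccc(C(=O)Nc5c(C)cccc5C)cc4s3)ncnc2cc1OCCCN1CCCCC1` likewise sits at a limit, > 100000 nM. The step from compound 2 to compound 3, in which a piperidin-1-yl replaces a pyrrolidin-1-yl, is a step that the two limits leave unreadable from compound 2 to compound 3, so it tells nothing about size or direction.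

Compound 4 `COc1cc2c(Nc3nc4ccc(C(=O)Nc5c(C)cc(C)cc5C)cc4s3)ncnc2cc1OCCCN1CCCCC1C` differs from compound 1 in one place: 2,4,6-trimethylphenyl in place of 2-chloro-6-methylphenyl on an amide-type nitrogen. Going by the values given here, no measured pair isolates this change, so no step of known size bears on it directly. What the measurements do show is the limit of > 100000 nM in this assay, at which 2 of the 3 values shown sit, and both compounds sitting there carry a 2,6-dimethylphenyl rather than the 2-chloro-6-methylphenyl of compound 1. On that basis a loss of potency is expected, with some chance that only a limit is returned. The expected step from compound 1 to compound 4 is a 5.7-fold higher number from compound 1 to compound 4 (0.75 log units; beyond the scatter). Compound 4 is therefore estimated at 30000 nM, within a range from 8000 nM to 120000 nM.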

Compound 4, half-maximal inhibitory concentration: 8800 nM
Compound 4: the middle estimate sits 3.4-fold (0.53 log units) above what was measured, within the range that was stated.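

On the amide-type nitrogen, replacing 2-chloro-6-methylphenyl with 2,4,6-trimethylphenyl gives a 1.7-fold higher number from compound 1 to compound 4 (0.22 log units; within the scatter), so this assay does not separate these two groups. For the compounds shown here, this is the first measured step at this position, and it shows that a phenyl group without chlorine can still return a number here when the rest of compound 1 is kept. Losing the chlorine therefore does not by itself bring a compound to the limit reached by compound 2 and compound 3: the limit of > 100000 nM in this assay, at which 2 of the 4 values shown sit.

This one step swaps the two groups whole, so it cannot show what the chlorine and the extra methyl each contribute; a 2-chloro-4,6-dimethylphenyl group would help to separate them. Going by these compounds, whether a 2,6-dichlorophenyl group on the same nitrogen would read alike also remains open.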